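Working notes: the step from compound 1 to compound 3

This account rests on a few compounds, and the source may have more. Where it says the series, first, only, none or still open, it means among the compounds named here.

compound 1 (`CN1CCN(c2cc(C(F)(F)F)nc(SCc3ccc(C(F)(F)F)cc3)n2)CC1`): 34700 nM
compound 2 (`CC(C)(C)OC(=O)N1CCN(c2cc(C(F)(F)F)nc(SCc3ccc(C(F)(F)F)cc3)n2)CC1`): 40600 nM

Both values come from a functional assay on PC-3 cells (Homo sapiens) for inhibition, read by MTT assay, with a stated time of 72 h; a higher number here means a weaker inhibitor, a lower number a stronger inhibitor. Within the data shown here, compound 1 stands level with compound 2, the only other measured compound, the step between them being a 1.2-fold higher number from compound 1 to compound 2 (0.07 log units; within the scatter).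

Compound 3 (`Cc1csc(Sc2cc(C(F)(F)F)nc(SCc3ccc(C(F)(F)F)cc3)n2)n1`) has not yet been measured in this assay. Its difference from compound 1 is (4-methyl-1,3-thiazol-2-yl)sulfanyl in place of 4-methylpiperazin-1-yl on an aromatic carbon, so a six-membered non-aromatic ring gives way to a five-membered aromatic ring.

Among the measured compounds shown here, only one measured step bears on this, and only loosely: a 1.2-fold higher number from compound 1 to compound 2 (0.07 log units; within the scatter) changes the group on the amine nitrogen and keeps the ring. For the measured compounds named here, no measured step covers the exchange of the whole group, so the expectation is weak and no direction can be given. No step beyond the scatter is expected in this assay. The expected step is estimated as a 1.2-fold lower number from compound 1 to compound 3 (0.06 log units; within the scatter). For compound 3 the estimate is 30000 nM, with an expected range from 10000 nM to 80000 nM.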

Compound 3, half-maximal inhibitory concentration: 12000 nM
Estimate against measurement, compound 3: 2.5-fold (0.40 log units) above; measured number inside the range.
By their numbers in this assay, from the lowest: compound 3; then compounds 1 and 2 (each within the scatter of the next).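

Exchanging the whole group on this aromatic carbon moves the number in this assay: (4-methyl-1,3-thiazol-2-yl)sulfanyl in place of 4-methylpiperazin-1-yl gives a 2.9-fold lower number from compound 1 to compound 3 (0.46 log units; beyond the scatter) as a modest change. The only earlier step, a 1.2-fold higher number from compound 1 to compound 2 (0.07 log units; within the scatter), altered the group on the amine nitrogen and kept the ring, so among these three compounds only the exchange of the whole group lies beyond the scatter. No available evidence bears on the origin of this step.

The compounds shown do not separate the contribution of the sulfanyl link from that of the five-membered aromatic ring, or show what the methyl on that ring contributes. An amine or ether link to the same ring, or a carboxylic acid in place of that methyl, would address these open points.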